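The source may hold more compounds than are shown below. What is called first, only, known or untested is meant among the compounds shown, and "the series" means these compounds.

Measured in a functional assay on HL-60 cells (Homo sapiens) for antiproliferative activity, read by MTT assay, with a stated time of 72 h; a higher number here means a weaker inhibitor, a lower number a stronger inhibitor:
- compound 1 `CC(C)(C)c1ccc(OCCCON2C(N)=NC(N)=NC23CCSCC3)cc1`: 280 nM
- compound 2 `NC1=NC2(CCSCC2)N(OCCCOc2ccc(Br)cc2)C(N)=N1`: 350 nM
- compound 3 `Cc1cc(C)cc(OCCCON2C(N)=NC(N)=NC23CCOCC3)c1`: 720 nM

In this assay, compound 2 gives 350 nM. This lies within the scatter of compound 1 at 280 nM, while compound 3 has the higher number, 720 nM.

The next compound is compound 4 `NC1=NC2(CCSCC2)N(OCCCOc2ccccc2Cl)C(N)=N1`, which has 2-chlorophenyl in place of 4-bromophenyl on an oxygen on a saturated carbon. For the measured compounds named here, only one measured step bears on this change: a 1.3-fold higher number from compound 1 to compound 2 (0.10 log units; within the scatter). That swap of tert-butyl for bromo on an aromatic carbon left the number within the scatter. Compound 3 differs from compound 2 in more than one place, so it isolates no single change. Going by the values given here, no measured compound carries a 2-chlorophenyl group, so the guidance is thin and the range must stay wide. No change beyond the scatter is expected, and the expected result is a 1.1-fold higher number from compound 2 to compound 4 (0.06 log units; within the scatter). For compound 4 the estimated value is 400 nM, with an expected range of 150 nM to 1100 nM.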

Compound 4, half-maximal inhibitory concentration: 390 nM
For compound 4 the middle estimate is 1.0-fold (0.01 log units) above the measured one; measured number inside the range.
By their numbers in this assay, from the lowest: compounds 1, 2, 4 and 3 (each within the scatter of the next, the first and the last beyond it).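

In this assay, putting 2-chlorophenyl in place of 4-bromophenyl on the oxygen on a saturated carbon gives a 1.1-fold higher number from compound 2 to compound 4 (0.05 log units; within the scatter) and stays within the scatter. The earlier step changed only the group on the aromatic carbon, from tert-butyl to bromo, whereas this one changes both the halogen and where it sits on the ring, and the number still does not move beyond the scatter. No measurement shown here gives a reason for this result.

Bromine and its ring location change together in this step, so the compounds shown cannot separate what each change does alone. On these data alone, whether an amine or a carboxylic acid on the same ring would also keep the number within the scatter remains open.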